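Trifluoromethyl on the Anilino Ring: Expectation Before Measurement

The source may hold more compounds than are shown below. What is called first, only, known or untested is meant among the compounds shown, and "the series" means these compounds.

Compound 1 `CCCCCCCCCCCCNc1nc(SCc2ccc(C(F)(F)F)cc2)nc2ccccc12`: in a functional assay on MDA-MB-231 cells (Homo sapiens) for cytotoxicity, read by MTT assay, with a stated time of 72 h (on this read-out lower numbers stand for stronger inhibition and higher numbers for weaker inhibition), compound 1 gives > 50000 nM, a limit of the assay.
Compound 2 `FC(F)(F)c1ccc(CSc2nc(Nc3ccccc3)c3ccccc3n2)cc1`: in this assay compound 2 gives 18400 nM.
Compound 3 `FC(F)(F)c1ccc(CSc2nc(Nc3ccccc3Cl)c3ccccc3n2)cc1`: in this assay compound 3 gives > 50000 nM, a limit of the assay.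

Compound 2 is thus the only one of the three with a number rather than a limit in this assay. Compound 4 `FC(F)(F)c1ccc(CSc2nc(Nc3cccc(C(F)(F)F)c3)c3ccccc3n2)cc1` differs from compound 2 by trifluoromethyl in place of hydrogen on an aromatic carbon. Within the data shown here, the only measured step on the same ring is an at least 2.7-fold higher number from compound 2 to compound 3 (0.43 log units; beyond the scatter), which ran up to the limit of > 50000 nM in this assay, at which 2 of the 3 values shown sit. A trifluoromethyl is a different group at a different place, so that step is a weak guide. Compound 4 is nevertheless expected to show a 1.9-fold higher number from compound 2 to compound 4 (0.28 log units; within the scatter), a weakening beyond the scatter. Compound 4 is estimated at 35000 nM, between 12000 nM and 100000 nM.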

Compound 4, half-maximal inhibitory concentration: 11100 nM
Beside the measured number, compound 4's estimate is 3.2-fold (0.50 log units) above it; the measured number lies below the stated range.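

In this assay, compound 4 is the first compound shown with a substituent on the anilino ring that gives a number rather than a limit, and trifluoromethyl at this place stays within the scatter: a 1.7-fold lower number from compound 2 to compound 4 (0.22 log units; within the scatter). Substitution on this ring therefore need not end at the limit, as the change of ring shows: an at least 4.5-fold lower number from compound 3 to compound 4 (0.65 log units; beyond the scatter). The full size of that step cannot be read, since compound 3 carries a limit of the assay: the limit of > 50000 nM in this assay, at which 2 of the 4 values shown sit.

The compounds shown leave open whether the 2-chlorophenyl to 3-(trifluoromethyl)phenyl step owes more to the group or to its place. They also leave open whether an amine or a carboxylic acid would fare like trifluoromethyl here.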